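A Smaller Amide Group on the Shared Core

The source may report more compounds than this note shows. Statements on the series, on what has been measured and on what is new or still open speak of the compounds shown alone.

Among the measured compounds shown here, compound 2 `O=C1O[C@@H](CNC(=O)C(F)(F)F)CN1c1ccc(-n2cc(-c3ccccn3)cn2)c(F)c1` is one of two compounds measured in a physicochemical assay for solubility, read by HPLC, with a stated time of 24 h; a higher number here means a more soluble compound, a lower number a less soluble compound. In this assay compound 2 gives 114000 nM, the higher of the two numbers. For the measured compounds named here, its only neighbour, compound 1 `CN(CCC#N)C[C@H]1CN(c2ccc(-n3cc(-c4ccccn4)cn3)c(F)c2)C(=O)O1`, gives 64500 nM, and the step of a 1.8-fold higher number from compound 1 to compound 2 (0.25 log units; within the scatter) is the single measured step, lying within the scatter. Compound 3 `CONC(=O)[C@H]1CN(c2ccc(-n3cc(-c4ccccn4)cn3)c(F)c2)C(=O)O1` has not been measured yet. It differs from compound 2 in one place: methoxycarbamoyl in place of (((trifluoromethyl)carbonyl)amino)methyl on a saturated ring carbon. Going by the values given here, the only measured step bears on it indirectly, since it also swapped one amide-bearing group for an amine-bearing one and left the number essentially where it was. Among the compounds with values here, no step moves beyond the scatter, so no change beyond the scatter is expected here either, with at most a slight rise. Compound 3 is therefore expected to give about 150000 nM, within a range from 60000 nM to 400000 nM. The step of a 1.3-fold higher number from compound 2 to compound 3 (0.12 log units; within the scatter) that this estimate means is expected to stay within the scatter.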

Compound 3, solubility: 78100 nM
Compound 3: the middle estimate sits 1.9-fold (0.28 log units) above what was measured; measured number inside the range.
By their numbers in this assay, from the lowest: compounds 1, 3 and 2 (each within the scatter of the next).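

This position tolerates quite different groups without a clear shift in this assay. Replacing (((trifluoromethyl)carbonyl)amino)methyl, with 8 heavy atoms, by methoxycarbamoyl, with 5, on the saturated ring carbon next to the ring oxygen gives a small step (a 1.5-fold lower number from compound 2 to compound 3 (0.16 log units; within the scatter)). The amine-bearing side chain of compound 1 and the methoxycarbamoyl group also stay close (a 1.2-fold higher number from compound 1 to compound 3 (0.08 log units; within the scatter)), so all three groups at this carbon give numbers within the usual scatter of one another. No supporting measurement offers an explanation for these results.

The compounds shown leave open whether a carboxylic acid or a primary amine on this ring carbon would move the number beyond the scatter. As far as these compounds go, the effect of a longer chain at this position also remains open.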